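The source may report more compounds than this note shows. Statements on the series, on what has been measured and on what is new or still open speak of the compounds shown alone.

Working notes on the series. In a functional assay on A549 cells (Homo sapiens) for cytotoxicity, read by MTT assay, with a stated time of 48 h (a lower number here means a stronger inhibitor, a higher number a weaker inhibitor), compound 1 (`CCOC(=O)C1(C(=O)Nc2ccccc2)CC1c1cc(OC)c(OC)c(OC)c1`) gives 31500 nM; 48600 nM (2 entries). Going by the values given here, compound 2 (`CCOC(=O)[C@]1(C(=O)Nc2ccccc2)C[C@H]1c1cc(OC)c(OC)c(OC)c1`) gives 37300 nM, the only single number so far, and it falls inside the span of the entries for compound 1. What separates the two is the fact that one of compounds 1 and 2 is drawn with a defined configuration and the other without, at the place where they differ, and their values lie within the scatter of each other.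

Compound 3 (`CCOC(=O)[C@]1(C(=O)Nc2ccccc2Cl)C[C@H]1c1cc(OC)c(OC)c(OC)c1`) departs from compound 2 by one change: chloro in place of hydrogen on an aromatic carbon. This is chloro in place of hydrogen on an aromatic carbon, turning phenylcarbamoyl into (2-chlorophenyl)carbamoyl. Among the compounds with values here, no measured compound yet carries a substituent at this place, so the series offers no step to carry over. The expectation therefore starts from compound 2 at 37300 nM and allows for a small move towards a lower number, with no shift beyond the scatter in this assay. The expected change is a 1.2-fold lower number from compound 2 to compound 3 (0.09 log units; within the scatter). For compound 3 the estimated value is 30000 nM, with an expected range from 12000 nM to 70000 nM.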

Compound 3, half-maximal inhibitory concentration: 13400 nM
Estimate against measurement, compound 3: 2.2-fold (0.35 log units) above; measured number inside the range.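

In this assay, the phenylcarbamoyl group proves to be a place where the number responds: chloro in place of hydrogen on an aromatic carbon, ortho to a large group, gives a 2.8-fold lower number from compound 2 to compound 3 (0.44 log units; beyond the scatter). Going by these compounds alone, compounds 1 and 2 could not show this, as they differ only in whether a configuration is drawn and their values lie within the scatter of each other, so this is the first change to move the number beyond the scatter, though only modestly. Nothing in the data at hand bears on the cause of this step.

The single step cannot tell whether the move belongs to chloro as such or to its place on the ring, and the compounds shown include neither a fluoro or methyl group at this position nor chloro elsewhere on the same ring. Also open, from the compounds shown here alone, is whether the step would carry over to other parts of the shared core, for instance with a carboxylic acid in place of the ethyl ester, or to a form drawn without a defined configuration.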